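Reading Compound 4 from Its Measured Neighbours

The compounds below may be only part of what the source reports. "The series", "measured", "known", "first", "only" and "open" are said of these compounds alone.

Measured in a functional assay for inhibition; a lower number here means a stronger inhibitor, a higher number a weaker inhibitor:
Compound 1 (`CC(C)(C)c1cc(-c2cc(=O)c3ccc(OCC(=O)N4CCN(Cc5ccccc5)CC4)cc3o2)cc(C(C)(C)C)c1O`) gives (3000 nM)
Compound 2 (`CC(C)(C)c1cc(-c2cc(=O)c3ccc(OCC(=O)O)cc3o2)cc(C(C)(C)C)c1O`) gives (3000 nM; 100 nM (2 entries))
Compound 3 (`CC(C)(C)c1cc(-c2cc(=O)c3ccc(OCc4ccc5ccccc5n4)cc3o2)cc(C(C)(C)C)c1O`) gives (3000 nM)

In this assay compound 3 gives 3000 nM and stands level with compound 1, within the scatter. Compound 2 offers a less firm reference, since its entries disagree (the several entries of compound 2 in this assay, 3000 nM; 100 nM (2 entries)).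

Compound 4 (`CC(C)(C)c1cc(-c2cc(=O)c3ccc(OCC(=O)N4CCCCC4)cc3o2)cc(C(C)(C)C)c1O`) is still unmeasured. It differs from compound 3 by carrying (piperidin-1-yl)carbonyl in place of quinolin-2-yl on a saturated chain carbon bound to an oxygen on an aromatic ring. Within the data shown here, no measured pair isolates this change, so any expectation remains loose. Compound 1 also has a carbonyl on that chain and gives 3000 nM, so no shift beyond the scatter is expected in this assay, in either direction. The expected change is small, with an estimate of a 1.5-fold lower number from compound 3 to compound 4 (0.18 log units; within the scatter) as the step. Compound 4 is estimated at 2000 nM (range 300 nM to 10000 nM).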

Compound 4, half-maximal inhibitory concentration: 3000 nM
Beside the measured number, compound 4's estimate is 1.5-fold (0.18 log units) below it, and the stated range covers the measured number.
By their numbers in this assay, from the lowest: compounds 1, 3 and 4 (each within the scatter of the next).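

In this assay, replacing quinolin-2-yl with (piperidin-1-yl)carbonyl on a saturated chain carbon bound to an oxygen on an aromatic ring gives no change at the digits printed from compound 3 to compound 4 (within the scatter). This is the first pair shown that differs in one place, so the position now has a direct reading rather than one inferred from separate compounds. Here, a group with two aromatic rings and a group with one non-aromatic ring and a carbonyl give the same number at the digits printed.

From the compounds shown here alone, what a primary amine or a small dimethylamide on this chain would give remains open. The carboxylic acid in compound 2 is the only group shown with any entry away from this level, and it gives no firm reference: the several entries of compound 2 in this assay, 3000 nM; 100 nM (2 entries)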